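Thromboxane receptor series: acyclic side chain variants

A few compounds are considered here, and "the series" means these few. Any claim that something is new, unique, unknown or untested is made for them only; others in the source may bear on it.

Measured compounds in a functional assay on a cell-free system (plasma) for inhibition of thromboxane A2 receptor (Homo sapiens); a lower number here means a stronger inhibitor, a higher number a weaker inhibitor:
compound 1 `CCCCSCSCC1C2CCC(O2)C1C/C=C\CCCC(=O)O`: 700 nM
compound 2 `O=C(O)CCC/C=C\CC1C2CCC(O2)C1CSCCc1ccccc1`: 5500 nM
compound 3 `CCCCCCCSCC1C2CCC(O2)C1C/C=C\CCCC(=O)O`: 42000 nM

Compound 3 gives the highest number of the three and is the weakest inhibitor in this assay; its nearest neighbour is compound 2, its furthest compound 1, both steps beyond the scatter.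

Compound 4 `CCC/C=C/CSCC1C2CCC(O2)C1C/C=C\CCCC(=O)O` is not yet measured. Relative to compound 3 it carries pent-1-en-1-yl in place of hexyl on a saturated chain carbon bound to a sulfur, so one chain carbon is lost and a double bond is gained.

Going by the values given here, two measured steps bear on this. a 60-fold higher number from compound 1 to compound 3 (1.78 log units; beyond the scatter) shows that replacing butylsulfanyl by hexyl at this position cost a large amount, and compound 4, like compound 3, keeps only one sulfur. a 7.6-fold higher number from compound 2 to compound 3 (0.88 log units; beyond the scatter) shows that an unsaturated group two bonds from the sulfur gave a modestly lower number than a saturated pentyl. A return toward unsaturation in compound 4 is therefore expected to give a modest improvement, a 3.5-fold lower number from compound 3 to compound 4 (0.54 log units; beyond the scatter), well short of the level of compound 1.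

Compound 4 is estimated at 12000 nM, within 4000 nM to 40000 nM.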

Compound 4, half-maximal inhibitory concentration: 1300 nM
The estimate for compound 4 lay 9.2-fold (0.97 log units) above the measured number, outside the stated range (below it).
By their numbers in this assay, from the lowest: compounds 1 and 4 (each within the scatter of the next); then compound 2; then compound 3.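

In this assay, a 32-fold lower number from compound 3 to compound 4 (1.51 log units; beyond the scatter), so at this place, on a saturated chain carbon bound to a sulfur, a single sulfur in the side chain does not by itself give a number as high as that of compound 3. Compound 4 carries no butylsulfanyl, yet a 1.9-fold higher number from compound 1 to compound 4 (0.27 log units; within the scatter), so the second sulfur of compound 1 is not needed to reach that level. Going by these compounds alone, the group also separates from benzyl, a 4.2-fold lower number from compound 2 to compound 4 (0.63 log units; beyond the scatter), so the earlier steps at this place did not predict what pent-1-en-1-yl would do.

The compounds shown do not separate the loss of one chain carbon from the gain of the double bond; pentyl at this same place, or the cis form of pent-1-en-1-yl, would bear on that. Nothing measured here accounts for the size of these steps.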